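A (5-chloropyrazin-2-yl)carbonyl group on compound 2

This account rests on a few compounds, and the source may have more. Where it says the series, first, only, none or still open, it means among the compounds named here.

In a physicochemical assay for solubility, read by spectrophotometry (a higher number here means a more soluble compound, a lower number a less soluble compound), compound 1 `O=C(Nc1ccc(C(F)(F)F)cc1)c1cc(Cl)ccc1O` reads < 100000 nM and this is a limit. Compound 2 `O=C(Nc1ccc(C(F)(F)F)cc1)c1cc(Br)ccc1O` reads < 100000 nM and this too is a limit, so it stands without a number of its own. Compound 3 `O=C(c1ccccc1)c1ccc(NC(=O)c2cc(Br)ccc2O)cc1` reads < 50000 nM and this is also a limit. Compound 4 `O=C(Oc1ccc(Br)cc1C(=O)Nc1ccc(C(F)(F)F)cc1)c1cnc(Cl)cn1` departs from compound 2 by (5-chloropyrazin-2-yl)carbonyl in place of hydrogen on an oxygen on an aromatic ring and neither measured step touches that oxygen. The measured record offers a step that the two limits leave unreadable from compound 1 to compound 2 and a step that the two limits leave unreadable from compound 2 to compound 3 and so gives no size to carry over. The expectation therefore leans only on compound 3 and its limit of < 50000 nM in a loose way, and points to a lower number. The estimated move is a step that the limit leaves unreadable from compound 2 to compound 4 with wide uncertainty. For compound 4 the expected value is 20000 nM within an estimated range from 3000 nM to 100000 nM in this assay.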

Compound 4, solubility: < 100000 nM
Compound 4 was reported as a limit; the forecaster's own chance of this, stated with the estimate: 55%; the middle value is on the limit's open side.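

Compound 2 and compound 4 are both reported only as limits, so the step between them cannot be read. The compounds shown leave open whether the (5-chloropyrazin-2-yl)carbonyl group on that oxygen changes solubility at all.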